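From propoxy to methylamino on the carbonyl carbon

A few compounds are considered here, and "the series" means these few. Any claim that something is new, unique, unknown or untested is made for them only; others in the source may bear on it.

Measured so far in a functional assay on PC-3 cells (Homo sapiens) for cytotoxicity, read by MTT assay, with a stated time of 72 h; on this read-out higher numbers stand for weaker inhibition and lower numbers for stronger inhibition
compound 1 `COC(=O)c1ccc(/C=C/C(=O)c2cc(OC)ccc2OC)cc1` gives 4850 nM
compound 2 `CCCOC(=O)c1ccc(/C=C/C(=O)c2cc(OC)ccc2OC)cc1` gives 26900 nM

Compound 2 (26900 nM) holds the higher of the two numbers, and so the weaker inhibition of the pair. Compound 3 `CNC(=O)c1ccc(/C=C/C(=O)c2cc(OC)ccc2OC)cc1` has not yet been measured. It differs from compound 2 by methylamino in place of propoxy on a carbonyl carbon and keeps the rest of the structure.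

Within the data shown here, the only measured step that bears on this is modest (a 5.5-fold higher number from compound 1 to compound 2 (0.74 log units; beyond the scatter)) and lies beyond the scatter. Among the measured compounds shown here, it lengthens the ester chain, and no measured compound shows an amide. A return only part of the way toward compound 1 (4850 nM) is therefore expected. The expected step in this assay is modest and goes toward a lower number (a 2.7-fold lower number from compound 2 to compound 3 (0.43 log units; beyond the scatter)). Compound 3 is estimated at 10000 nM (expected range 3000 nM to 35000 nM).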

Compound 3, half-maximal inhibitory concentration: 2130 nM
Compound 3: middle estimate off by 4.7-fold (0.67 log units), on the high side; the measured number lies below the stated range.
By their numbers in this assay, from the lowest: compound 3; then compound 1; then compound 2.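

In this assay the carbonyl carbon proves to respond to more than the length of an ester chain: methylamino in place of propoxy gives a 13-fold lower number from compound 2 to compound 3 (1.10 log units; beyond the scatter) and methylamino in place of methoxy gives a 2.3-fold lower number from compound 1 to compound 3 (0.36 log units; beyond the scatter) so the amide compound 3 goes past compound 1 rather than falling between the two esters. Among these compounds, then, the kind of group on this carbon matters as well as its size. Nothing available here accounts for the gain.

With a single amide, the compounds leave open whether the amide hydrogen matters, which dimethylamino on the same carbon would test. They also leave open whether a longer chain on the nitrogen, such as propylamino, costs as much as propoxy does, and how a carboxylic acid would compare.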